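The source may report more compounds than this note shows. Statements on the series, on what has been measured and on what is new or still open speak of the compounds shown alone.

Measured so far in a functional assay on U-87MG ATCC cells for antiproliferative activity against U-87 MG (Homo sapiens), read by MTT assay, with a stated time of 48 h, tested at 10 uM; on this read-out lower numbers stand for a stronger effect and higher numbers for a weaker effect at the one concentration tested:
Compound 1 `COc1ccc(-c2nc(C)c(C(=O)CSc3nc(-c4ccc(OC)c(OC)c4)c(C#N)c(=O)[nH]3)s2)cc1` gives 57.6%.
Compound 2 `Cc1nc(-c2ccccc2)sc1C(=O)CSc1nc(-c2ccc(Cl)c(Cl)c2)c(C#N)c(=O)[nH]1` gives 92.5%.

Compound 2 stands highest of the two numbers; compound 1 lies well below it, beyond the usual scatter. Compound 3 `COc1ccc(-c2nc(C)c(C(=O)CSc3nc(-c4ccc(Cl)c(Cl)c4)c(C#N)c(=O)[nH]3)s2)cc1` differs from compound 2 by methoxy in place of hydrogen on an aromatic carbon. Since compound 1 carries that same methoxy among its differences from compound 2, a lowering of the number, towards a stronger effect, is expected, but its size is uncertain because compound 1 at 57.6% and compound 2 at 92.5% are its only anchors. The step from compound 2 to compound 3 is estimated at a number 16.5 percentage points lower from compound 2 to compound 3 (beyond the scatter). Compound 3 is therefore expected at 76%, with a range from 56% to 96%.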

Compound 3, a percentage reported as activity, at one concentration (the size of the read-out at that concentration, not a potency): 88.6%
Compound 3: the middle estimate sits 12.6 percentage points below what was measured; the measured number falls inside the stated range.
By their numbers in this assay, from the lowest: compound 1; then compounds 3 and 2 (each within the scatter of the next).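

In this assay, phenyl to 4-methoxyphenyl alone amounts to a number 3.9 percentage points lower from compound 2 to compound 3 (within the scatter), so this methoxy in place of hydrogen on an aromatic carbon does not reproduce the gap between compound 1 and compound 2. That gap instead appears with the exchange of 3,4-dimethoxyphenyl for 3,4-dichlorophenyl, at a number 31 percentage points higher from compound 1 to compound 3 (beyond the scatter). Nothing measured here gives a reason for either step.

The compounds shown leave open how an amine or a carboxylic acid in place of this methoxy would read. They also leave open whether a single methoxy on the other aryl group would suffice.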